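Fluoro to hydrogen on the aryl of compound 1

The compounds below may be only part of what the source reports. "The series", "measured", "known", "first", "only" and "open" are said of these compounds alone.

Three compounds of this series carry a measurement in a functional assay, read by spectrophotometry, with a stated time of 15 min, tested at 40 ug/mL; a higher number here means a stronger effect of the compound at the concentration tested, a lower number a weaker effect. Compound 1 `Fc1ccc(-c2csc(N/N=C/c3ccc(Cl)cc3Cl)n2)cc1` gives 93.3% in this assay. Compound 2 `Fc1ccc(-c2csc(N/N=C/c3cccs3)n2)cc1` gives 93.3%, which at the digits shown does not differ from the number of compound 1 and lies within the usual scatter, so the two sit together at the top of the three values. Compound 3 `COC(=O)c1cc(-c2csc(N/N=C/c3ccc(Cl)cc3Cl)n2)ccc1OCc1ccccc1` gives 37.2%, a number well below the other two and beyond the scatter. Within the data shown here, no pair of these measured compounds differs in only one place, so no single-point step has been quantified so far.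

Compound 4 `Clc1ccc(/C=N/Nc2nc(-c3ccccc3)cs2)c(Cl)c1` has not yet been tested in this assay. It differs from compound 1 in one place: hydrogen in place of fluoro on an aromatic carbon. The change removes a single fluorine and leaves the remainder of the structure untouched. Among the measured compounds shown here, with no comparable step measured, the expectation rests on the small size of the change and on the high read-out of compound 1 at 93.3%; a step of a number 5.3 percentage points lower from compound 1 to compound 4 (within the scatter) is expected, that is, nothing beyond the scatter, if anything a slight drop. Compound 4 is therefore estimated at 88%, with a range from 70% to 97%.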

Compound 4, a percentage reported as inhibition, at one concentration (the size of the read-out at that concentration, not a potency): 90.2%
For compound 4 the middle estimate is 2.2 percentage points below the measured one; the range from low to high includes it.
By their numbers in this assay, from the lowest: compound 3; then compounds 4, 1 and 2 (each within the scatter of the next).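

The series now has its first single-point step in this assay: the change 4-fluorophenyl to phenyl gives a number 3.1 percentage points lower from compound 1 to compound 4 (within the scatter). With the rest of compound 1 held fixed, the fluoro group at this place on the aromatic ring is therefore not needed to keep the read-out in the range of compound 1 at the concentration tested, although a read-out at one concentration is not a potency and could leave a difference between the two compounds unseen. Nothing available gives a measured reason for this result or for any property of the fluoro group at this position.

On these data alone, at this ring carbon only fluoro and hydrogen are covered, so the effect of an amine, a carboxylic acid, a methoxy group or a longer alkyl chain in the same place remains open. As far as these compounds go, it also remains open whether the same exchange of fluoro for hydrogen would give a comparable step on compound 2, where the other end of the molecule differs.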